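Working notes: the step from compound 2 to compound 3

A few compounds are considered here, and "the series" means these few. Any claim that something is new, unique, unknown or untested is made for them only; others in the source may bear on it.

Measured so far in an ADME assay on a cell-free system (serum) for metabolic stability; on this read-out higher numbers stand for a longer-lived compound and lower numbers for a shorter-lived compound
- Compound 1 `CC(C)(C)c1cc(OC(=O)c2c(Cl)cc(N)cc2Cl)ccc1O` gives < 0.25 h, a limit
- Compound 2 `CC(C)(C)c1cc(NC(=O)c2c(Cl)cc(NCc3ccncc3)cc2Cl)ccc1O` gives > 1 h, a limit

Compound 2 stands at > 1 h, which is a limit and not a number. Compound 3 `CNc1cc(Cl)c(C(=O)Nc2ccc(O)c(C(C)(C)C)c2)c(Cl)c1` is not yet measured. It differs from compound 2 in one place: hydrogen in place of pyridin-4-yl on a saturated chain carbon bound to a nitrogen on an aromatic ring, with hydrogen in place of pyridin-4-yl on a saturated chain carbon bound to a nitrogen on an aromatic ring. In other words, ((pyridin-4-yl)methyl)amino becomes methylamino. Within the data shown here, no measured pair shows this change, so the expectation is loose. In this assay no step beyond the scatter is expected, with the estimated step being a step that the limit leaves unreadable from compound 2 to compound 3 in size. For compound 3 the estimate is 1.5 h, with an expected range from 0.7 h to 5 h.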

Compound 3, half-life: > 1 h
Compound 3 ended at the assay's limit (the forecaster's own chance of this, stated with the estimate: 60%); the middle value lies beyond the limit too.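

No step from compound 2 to compound 3 can be read in this assay, since both values are limits and not numbers: the limit of > 1 h in this assay, at which 2 of the 3 values shown sit.

The compounds shown leave open how far the half-life of either compound lies past that limit, and whether hydrogen in place of pyridin-4-yl changes it at all.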